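Series notes: dimethylamino in place of hydrogen on compound 1

The compounds below may be only part of what the source reports. "The series", "measured", "known", "first", "only" and "open" are said of these compounds alone.

Measured so far in a functional assay on MOLT-4 cells (Homo sapiens) for inhibition; on this read-out higher numbers stand for weaker inhibition and lower numbers for stronger inhibition:
- compound 1 `O=C1/C(=C/c2ccccc2)CCc2ccccc21`: 32400 nM
- compound 2 `O=C1/C(=C/c2cccc(F)c2)CCc2ccccc21`: 11900 nM
- compound 3 `Cc1cccc(/C=C2\CCc3ccccc3C2=O)c1`: 35800 nM

Compound 1 stands second highest of the three numbers; compound 3 lies within the scatter of it, while compound 2 gives the lowest number. Compound 4 `CN(C)c1ccc(/C=C2\CCc3ccccc3C2=O)cc1` differs from compound 1 by dimethylamino in place of hydrogen on an aromatic carbon. Both known steps also replace an aromatic hydrogen, a 2.7-fold lower number from compound 1 to compound 2 (0.43 log units; beyond the scatter) and a 1.1-fold higher number from compound 1 to compound 3 (0.04 log units; within the scatter), so substitution on this ring has given at most a modest change in this assay, and none in one case. Going by the values given here, no step is known at the place para to a large group. A modest lowering or no change beyond the scatter is expected. Compound 4 is estimated at 20000 nM (range 6000 nM to 60000 nM), an expected step of a 1.6-fold lower number from compound 1 to compound 4 (0.21 log units; within the scatter).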

Compound 4, half-maximal inhibitory concentration: 2110 nM
Estimate against measurement, compound 4: 9.5-fold (0.98 log units) above; measured number outside the range, below it.
By their numbers in this assay, from the lowest: compound 4; then compound 2; then compounds 1 and 3 (each within the scatter of the next).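

In this assay the place para to a large group proves highly responsive to dimethylamino (a 15-fold lower number from compound 1 to compound 4 (1.19 log units; beyond the scatter)). This step is larger than those for the two earlier replacements of an aromatic hydrogen (a 2.7-fold lower number from compound 1 to compound 2 (0.43 log units; beyond the scatter)) and (a 1.1-fold higher number from compound 1 to compound 3 (0.04 log units; within the scatter)). Substitution on this ring can therefore do more than the earlier compounds showed.

From the compounds shown here alone, whether the gain belongs to dimethylamino or to the place remains open; a primary amine, a methoxy group or a carboxylic acid at this place would help separate the two. No measurement at hand bears on what underlies the step.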